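Isoxazole substituent swap: from thiophene to isopropyl

The source may hold more compounds than are shown below. What is called first, only, known or untested is meant among the compounds shown, and "the series" means these compounds.

Three members of the series share one core and differ only in the group on the five-membered ring carrying one nitrogen and one oxygen. In an assay on isolated protein for inhibition of proto-oncogene tyrosine-protein kinase receptor Ret (Homo sapiens), read by radiometric assay and 33P incorporation, in the presence of a further agent that is not named here (a higher number here means a weaker inhibitor, a lower number a stronger inhibitor), compound 1 `Cc1ccc(-c2cc(-c3nn(C(C)C)c(N)c3C(N)=O)no2)cc1` gives 1660 nM, compound 2 `CC(C)n1nc(-c2cc(-c3cccnc3)on2)c(C(N)=O)c1N` gives 3400 nM, and compound 3 `CC(C)n1nc(-c2cc(-c3cccs3)on2)c(C(N)=O)c1N` gives 78 nM. Compound 3 holds the lowest number of the three: its steps to both others, a 21-fold lower number from compound 1 to compound 3 (1.33 log units; beyond the scatter) and a 44-fold lower number from compound 2 to compound 3 (1.64 log units; beyond the scatter), are large, while a 2.0-fold higher number from compound 1 to compound 2 (0.31 log units; beyond the scatter) is modest.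

Compound 4 `CC(C)c1cc(-c2nn(C(C)C)c(N)c2C(N)=O)no1` is unmeasured. Relative to compound 3 the change is isopropyl in place of thiophen-2-yl on an aromatic carbon. Among the compounds with values here, the steps that bear on it are the two into compound 3 from the aryl and pyridyl analogues, both large and both toward lower numbers; no measured step covers a group without a ring at this position. Removing the ring that carried the large gain is expected to give back much of it, so a step toward a higher number is expected, a 12-fold higher number from compound 3 to compound 4 (1.06 log units; beyond the scatter). Compound 4 is estimated at 900 nM, with a range from 150 nM to 5000 nM.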

Compound 4, half-maximal inhibitory concentration: 1260 nM
Compound 4: the middle estimate sits 1.4-fold (0.15 log units) below what was measured, within the range that was stated.
By their numbers in this assay, from the lowest: compound 3; then compounds 4 and 1 (each within the scatter of the next); then compound 2.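

In this assay the isopropyl group does not keep the level reached with thiophen-2-yl, with a 16-fold higher number from compound 3 to compound 4 (1.21 log units; beyond the scatter). A ring at this position is therefore not needed to match the 4-methylphenyl compound, since a 1.3-fold lower number from compound 1 to compound 4 (0.12 log units; within the scatter), and the group without a ring also improves on pyridin-3-yl, with a 2.7-fold lower number from compound 2 to compound 4 (0.43 log units; beyond the scatter). Among the four groups shown, the low number thus belongs to thiophen-2-yl alone rather than to ring-bearing groups in general, and no evidence is available here that bears on the reason.

As far as these compounds go, it remains open whether the low number extends to close relatives such as thiophen-3-yl or furan-2-yl. From the compounds shown here alone, it is equally open how a smaller group such as methyl, a longer alkyl chain or an amine on this carbon would compare with isopropyl.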